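The source may hold more compounds than are shown below. What is called first, only, known or untested is meant among the compounds shown, and "the series" means these compounds.

In a functional assay on Raji cells (Homo sapiens) for cytotoxicity, with a stated time of 72 h (a higher number here means a weaker inhibitor, a lower number a stronger inhibitor), compound 1 `O=C(/C=C/C=C/C=C/C=C/c1ccc[nH]1)OCc1ccccc1` gives 1400 nM, a measured number. Compound 2 `CCOC(=O)/C=C/C=C/C=C/C=C/c1[nH]ccc1Cl` gives > 10000 nM, and this is a limit of the assay and not a number. Among the compounds with values here, compound 2 therefore has no exact place on the scale, and no step from it can yet be read. Compound 3 `O=C(/C=C/C=C/C=C/C=C/c1[nH]ccc1Cl)OCc1ccccc1` follows from compound 2 through (phenyl in place of methyl on a saturated chain carbon bound to an oxygen next to a carbonyl group), with phenyl in place of methyl on a saturated chain carbon bound to an oxygen next to a carbonyl group, which turns ethoxy into benzyloxy. A step towards stronger inhibition, clearly beyond the scatter, is expected in this assay because compound 1 gives 1400 nM with the same benzyloxy group. The expected change is an at least 6.6-fold lower number from compound 2 to compound 3 (0.82 log units; beyond the scatter). Compound 3 is estimated at 1500 nM, with an expected range of 400 nM to 6000 nM.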

Compound 3, half-maximal inhibitory concentration: 6700 nM
The estimate for compound 3 lay 4.5-fold (0.65 log units) below the measured number; measured number outside the range, above it.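

In this assay, ethoxy to benzyloxy on the chloro-bearing core gives an at least 1.4-fold lower number from compound 2 to compound 3 (0.17 log units; that floor lies within the scatter), so this change at the saturated chain carbon bound to an oxygen next to a carbonyl group brings the series onto the measured scale, although the printed floor alone does not establish a real gain. As far as these compounds go, compound 2 stands at a limit of the assay and not at a number, and the true size of the step stays unknown because of it: the limit of > 10000 nM in this assay, at which 1 of the 3 values shown sits. Within the data shown here, with benzyloxy held constant, chloro in place of hydrogen on an aromatic carbon gives a 4.8-fold higher number from compound 1 to compound 3 (0.68 log units; beyond the scatter), the one step here with two measured ends, and it runs towards weaker inhibition.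

From the compounds shown here alone, whether chloro has the same effect when ethoxy replaces benzyloxy remains open. Also open, going by these compounds, is how fluoro or bromo at that aromatic carbon, or a carboxylic acid in place of the benzyloxy ester, would compare.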